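Replacing piperidin-1-yl with (4-bromophenyl)amino on the shared core

A few compounds are considered here, and "the series" means these few. Any claim that something is new, unique, unknown or untested is made for them only; others in the source may bear on it.

Compound 1 `CC(=O)c1c(Nc2ccc(F)cc2F)[nH]c2c(Cl)cc(Cl)c(Cl)c2c1=O`: > 25000 nM, a limit
Compound 2 `CC(=O)c1c(N2CCCCC2)[nH]c2c(F)cc(F)cc2c1=O`: > 25000 nM, a limit
Compound 3 `CC(=O)c1c(OCc2ccc(Cl)c(Cl)c2)[nH]c2c(F)cc(F)cc2c1=O`: > 25000 nM, a limit

In an ADME assay on Vero cells (Chlorocebus sabaeus) for cytotoxicity (on this read-out lower numbers stand for higher toxicity in this test and higher numbers for lower toxicity in this test), compound 2 gives > 25000 nM, which is a limit and not a number. It has no standing of its own among the measured compounds, which share a single reading: the limit of > 25000 nM in this assay, at which 3 of the 3 values shown sit.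

The next compound is compound 4 `CC(=O)c1c(Nc2ccc(Br)cc2)[nH]c2c(F)cc(F)cc2c1=O`. It carries (4-bromophenyl)amino in place of the piperidin-1-yl of compound 2, on an aromatic carbon next to the ring nitrogen and ortho to the acetyl group: (4-bromophenyl)amino in place of piperidin-1-yl on an aromatic carbon. Among the compounds with values here, no measured pair in this set differs in one place only, so the size of this step can only be judged indirectly. Compound 1 also has an aromatic ring on an amino group, and its > 25000 nM is again a limit.

No step beyond the usual scatter is expected in this assay, and any shift that does appear is expected toward lower numbers. The expected change is a number no higher from compound 2 to compound 4 (the limit leaves the size open). For compound 4 the estimated value is 25000 nM, with an expected range from 10000 nM to 40000 nM.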

Compound 4, half-maximal cytotoxic concentration: > 25000 nM
Compound 4 ended at the assay's limit; the forecaster's own chance of this, stated with the estimate: 75%; the middle value lies on the limit itself.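

In this assay compound 4 gives > 25000 nM, which is a limit and not a number. Compound 2 also stands at a limit, so no step can be read between compound 2 and compound 4. The compounds shown leave open where their true values lie and whether any change on the shared core would move a reading off this limit.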